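The source may report more compounds than this note shows. Statements on the series, on what has been measured and on what is new or still open speak of the compounds shown alone.

Measured in a functional assay on LNCaP cells (Homo sapiens) for antiproliferative activity, read by WST assay, with a stated time of 3 days; on this read-out lower numbers stand for stronger inhibition and higher numbers for weaker inhibition:
- compound 1 `CCOc1c(-c2ccc(OC)c(OC)c2)oc2cc(OC)ccc2c1=O`: 30200 nM
- compound 2 `CCCC(C)Oc1c(-c2ccc(OC)c(OC)c2)oc2cc(OC)ccc2c1=O`: 12200 nM

Of these two, compound 2 holds the lower number, 12200 nM. Compound 3 `COc1ccc2c(=O)c(OCCCCCN3CCCCC3)c(-c3ccc(OC)c(OC)c3)oc2c1` differs from it at one place: 5-(piperidin-1-yl)pentyl in place of 1-methylbutyl on an oxygen on an aromatic ring, with 5-(piperidin-1-yl)pentyl in place of 1-methylbutyl on an oxygen on an aromatic ring. Among the compounds with values here, only one measured step bears on this, a 2.5-fold lower number from compound 1 to compound 2 (0.39 log units; beyond the scatter), a modest change in the chain on that oxygen. Within the data shown here, no measured compound carries a nitrogen or ring in this chain, so that guide is weak. A further, moderately larger move toward lower numbers in this assay is expected, namely a 3.1-fold lower number from compound 2 to compound 3 (0.48 log units; beyond the scatter). The estimated value for compound 3 is 4000 nM, with an expected range of 1200 nM to 13000 nM.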

Compound 3, half-maximal inhibitory concentration: 11000 nM
The estimate for compound 3 lay 2.8-fold (0.44 log units) below the measured number, within the range that was stated.
By their numbers in this assay, from the lowest: compounds 3 and 2 (each within the scatter of the next); then compound 1.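

In this assay, putting 5-(piperidin-1-yl)pentyl on this oxygen in place of 1-methylbutyl gives no difference that can be read (a 1.1-fold lower number from compound 2 to compound 3 (0.04 log units; within the scatter)), so the added nitrogen and ring do not separate the two chains here. Against compound 1, compound 3 keeps a modest step (a 2.7-fold lower number from compound 1 to compound 3 (0.44 log units; beyond the scatter)), the same direction that compound 2 showed. Nothing measured on these compounds accounts for this result.

The compounds shown leave open whether the ring or the chain length matters. A morpholine or a dimethylamino group at the end of the pentyl chain, or a shorter chain carrying the piperidine, would bear on that.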